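Hexyl to hydroxy on the chain of compound 2

A few compounds are considered here, and "the series" means these few. Any claim that something is new, unique, unknown or untested is made for them only; others in the source may bear on it.

Among the compounds with values here, compound 2 `CCCCCCCCn1nc(-c2cccnc2)c2ccccc2c1=O` stands highest of the three measured members: in an assay on isolated protein (Oryctolagus cuniculus) with Thromboxane-A synthase (Homo sapiens) as the target, tested at 1 uM (on this read-out higher numbers stand for more inhibition at the one concentration tested (going by the name of the read-out) and lower numbers for less inhibition), compound 2 gives 99%. Compound 1 `CCn1nc(-c2cccnc2)c2ccccc2c1=O` gives 87%, and compound 3 `O=c1c2ccccc2c(-c2cccnc2)nn1CCSc1ncccn1` gives 86%. Compound 4 `O=c1c2ccccc2c(-c2cccnc2)nn1CCO` carries hydroxy in place of hexyl on a saturated chain carbon, two bonds along the chain from an aromatic nitrogen. Within the data shown here, the steps that bear on this are a number 12 percentage points higher from compound 1 to compound 2 (beyond the scatter) and a number 13 percentage points lower from compound 2 to compound 3 (beyond the scatter), both at the same saturated chain carbon, two bonds along the chain from an aromatic nitrogen; the step of a number 1 percentage points lower from compound 1 to compound 3 (within the scatter) shows hydrogen and (pyrimidin-2-yl)sulfanyl standing close together there. Removing hexyl is therefore expected to cost a modest step, and the step from compound 2 to compound 4 is estimated as a number 17 percentage points lower from compound 2 to compound 4 (beyond the scatter). Compound 4 is expected to give 82%, with a range from 62% to 94%.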

Compound 4, a percentage reported as inhibition, at one concentration (the size of the read-out at that concentration, not a potency): 69%
Compound 4: the middle estimate sits 13 percentage points above what was measured, within the range that was stated.
By their numbers in this assay, from the lowest: compound 4; then compounds 3 and 1 (each within the scatter of the next); then compound 2.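

In this assay this carbon now shows a loss as well as a gain: hydroxy falls below hydrogen beyond the scatter (a number 18 percentage points lower from compound 1 to compound 4 (beyond the scatter)), whereas (pyrimidin-2-yl)sulfanyl had stood level with hydrogen. Hydroxy also sits below that sulfur-linked group (a number 17 percentage points lower from compound 3 to compound 4 (beyond the scatter)), and its replacement of hexyl gives the widest step in the series (a number 30 percentage points lower from compound 2 to compound 4 (beyond the scatter)). No measurement shown accounts for this drop.
As far as these compounds go, whether the loss is particular to hydroxy stays open. Methoxy, an amine or a carboxylic acid at this carbon would test that.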